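Methoxy to dimethylamino: the step from compound 2 to compound 4

The compounds below may be only part of what the source reports. "The series", "measured", "known", "first", "only" and "open" are said of these compounds alone.

Three measured compounds share one core: compound 1 `O=C(O)Cc1sc(C(c2ccccc2)c2ccccc2)nc1-c1ccc(C(F)(F)F)cc1`, compound 2 `COc1cc(-c2nc(C(c3ccc(F)cc3)c3ccc(F)cc3)sc2CC(=O)O)ccn1` and compound 3 `O=C(O)Cc1sc(CSc2ccccc2)nc1-c1ccc(Cl)cc1`. In an in vitro assay on HEK385-7 cells for displacement of a labelled ligand from prostaglandin D2 receptor 2 (Homo sapiens) (on this read-out higher numbers stand for weaker inhibition and lower numbers for stronger inhibition), compound 2 gives 29 nM, the lowest of the three numbers; compound 3 gives 250 nM and compound 1 gives 1100 nM, both beyond the scatter from compound 2. Among the compounds with values here, no pair of these differs in one place only, so no single-change step is available as a guide. Compound 4 `CN(C)c1cc(-c2nc(C(c3ccc(F)cc3)c3ccc(F)cc3)sc2CC(=O)O)ccn1` is not yet measured; it differs from compound 2 as follows: dimethylamino in place of methoxy on an aromatic carbon. Without a comparable step among the measured compounds, the expected change a 1.2-fold higher number from compound 2 to compound 4 (0.08 log units; within the scatter) is small, most likely within the scatter in either direction. Compound 4 is therefore estimated at 35 nM, with a range from 12 nM to 100 nM.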

Compound 4, half-maximal inhibitory concentration: 380 nM
Compound 4: the middle estimate sits 11-fold (1.04 log units) below what was measured, outside the stated range (above it).
By their numbers in this assay, from the lowest: compound 2; then compounds 3 and 4 (each within the scatter of the next); then compound 1.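

In this assay the swap of methoxy for dimethylamino next to the ring nitrogen gives a 13-fold higher number from compound 2 to compound 4 (1.12 log units; beyond the scatter) and is a large step. Within the data shown here, this is the first single-change reading, and it shows that this position does not tolerate every exchange, even though both groups count the same hydrogen-bond acceptors. Nothing available accounts for the size of this step.
Still open, as far as these compounds go, is whether an ethoxy group, a methylamino group or a primary amine at this place stays near compound 2 or falls nearer compound 4.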